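From a limit at compound 3 to a benzyl amide

The compounds below may be only part of what the source reports. "The series", "measured", "known", "first", "only" and "open" are said of these compounds alone.

In an ADME assay on BaF3 cells (Mus musculus) for antiproliferative activity, read by CCK-8 assay, with a stated time of 72 h (a lower number here means a stronger inhibitor of growth, a higher number a weaker inhibitor of growth), compound 1 `O=C(CCSc1ccc2c(/C=C/c3ccccn3)n[nH]c2c1)Nc1cccc(Cl)c1` gives 9350 nM and compound 2 `COc1cccc(NC(=O)CCSc2ccc3c(/C=C/c4ccccn4)n[nH]c3c2)c1` gives 3840 nM on a shared core. In this assay compound 3 `Cc1ccc(NC(=O)CCSc2ccc3c(/C=C/c4ccccn4)n[nH]c3c2)cc1` returns only a limit, > 10000 nM. Compound 4 `O=C(CCSc1ccc2c(/C=C/c3ccccn3)n[nH]c2c1)NCc1cccc(C(F)(F)F)c1` differs from compound 3 on an amide-type nitrogen (3-(trifluoromethyl)benzyl in place of 4-methylphenyl on an amide-type nitrogen), with 3-(trifluoromethyl)benzyl in place of 4-methylphenyl. The measured steps bear on this only loosely, since all of them keep a phenyl ring on that nitrogen and none brings in a benzyl. The step of a 2.4-fold lower number from compound 1 to compound 2 (0.39 log units; beyond the scatter) is modest, the step of an at least 2.6-fold higher number from compound 2 to compound 3 (0.41 log units; beyond the scatter) is at least modest, and the step of an at least 1.0-fold higher number from compound 1 to compound 3 (0.02 log units; that floor lies within the scatter) has a floor within the scatter. With only steps of that order to go on, a modest shift is the most that can be expected, and the range stays wide. The expected change is an at least 1.5-fold lower number from compound 3 to compound 4 (0.18 log units; that floor lies within the scatter), small and towards a lower number if it shows at all. For compound 4 the estimated value is 6500 nM, with an expected range of 2500 nM to 10000 nM.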

Compound 4, concentration for 50% growth inhibition: 8030 nM
Estimate against measurement, compound 4: 1.2-fold (0.09 log units) below; measured number inside the range.
By their numbers in this assay, from the lowest: compound 2; then compounds 4 and 1 (each within the scatter of the next). At a limit, above all of these: compound 3.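

In this assay, a benzyl on this amide-type nitrogen still gives a measured number: a 1.2-fold lower number from compound 1 to compound 4 (0.07 log units; within the scatter), while a 2.1-fold higher number from compound 2 to compound 4 (0.32 log units; beyond the scatter), so compound 2 keeps the lowest number of the compounds shown. Against the 4-methylphenyl compound the result gives no size for the change, as an at least 1.2-fold lower number from compound 3 to compound 4 (0.09 log units; that floor lies within the scatter) is all that can be read. Compound 3 stands at a limit and not at a number: the limit of > 10000 nM in this assay, at which 1 of the 4 values shown sits.

The compounds shown do not separate the effect of the benzyl link from that of the trifluoromethyl group, as these two enter together in compound 4. Going by these compounds, how a plain benzyl, a longer chain on this nitrogen or an amine on the ring would read in this assay stays open.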